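Halogenated Aryl Ureas on a Shared Diaryl Ether Core

This account rests on a few compounds, and the source may have more. Where it says the series, first, only, none or still open, it means among the compounds named here.

Compound 3 `O=C(Nc1ccccc1)Nc1ccc(Oc2ccc(-c3ncc[nH]3)cc2)cc1` was tested in a functional assay on A549 cells (Homo sapiens) for inhibition, read by MTT assay and WST assay, with a stated time of 72 h, tested at 10 uM (a higher number here means more inhibition of growth at the concentration tested, a lower number less inhibition of growth), where compound 3 gives 7.09%, the lowest of the three numbers in hand. Its nearest neighbour is compound 1 `Cc1ccc(NC(=O)Nc2ccc(Oc3ccc(-c4nccs4)cc3)cc2)cc1`, which in this assay gives 15.6%, a gap that stays within the scatter. Compound 2 `O=C(Nc1ccc(Oc2ccc(-c3nccs3)cc2)cc1)Nc1ccc(F)c(Cl)c1` stands furthest away; in this assay compound 2 gives 37.3%, a gap from compound 3 that lies beyond the scatter.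

Compound 4 `O=C(Nc1ccc(Oc2ccc(-c3ncc[nH]3)cc2)cc1)Nc1cc(C(F)(F)F)ccc1Cl` differs from compound 3 in one place: 2-chloro-5-(trifluoromethyl)phenyl in place of phenyl on an amide-type nitrogen. Going by the values given here, the single measured step that bears on this change is the one in which 3-chloro-4-fluorophenyl replaced 4-methylphenyl on the same kind of amide-type nitrogen, with the result a number 21.7 percentage points higher from compound 1 to compound 2 (beyond the scatter). That pair is built on a core that differs from the shared core of compound 3 and compound 4, so the precedent is not exact, yet it is the only one available, its direction is upward and its size modest.

On that basis a step of comparable size and the same direction is expected for compound 4, namely a number 20.9 percentage points higher from compound 3 to compound 4 (beyond the scatter). Compound 4 is therefore estimated to give 28% in this assay, with a range from 10% to 50%.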

Compound 4, percent growth inhibition at one concentration: 22.3%
Beside the measured number, compound 4's estimate is 5.7 percentage points above it; low and high end bracket the measured number.
By their numbers in this assay, from the lowest: compounds 3, 1 and 4 (each within the scatter of the next, the first and the last beyond it); then compound 2.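

On the shared core of compound 3 and compound 4, the amide-type nitrogen tolerates a much larger aryl group with a gain rather than a loss: in this assay, 2-chloro-5-(trifluoromethyl)phenyl in place of phenyl brings a number 15.2 percentage points higher from compound 3 to compound 4 (beyond the scatter) on this core. Going by these compounds alone, until now, a halogen-bearing aryl group on this nitrogen had been seen to raise the number only on the core of compound 1, with a number 21.7 percentage points higher from compound 1 to compound 2 (beyond the scatter) as the sole example, and there the group it replaced was 4-methylphenyl; the new step shows the same direction on a second core and from an unsubstituted phenyl. No measurement at hand accounts for either rise.

The compounds shown do not separate the chlorine from the trifluoromethyl group in this step, and they do not tell whether 2-chloro-5-(trifluoromethyl)phenyl would bring a like step on the core of compound 1. They also leave open how an aryl group carrying an amine or a carboxylic acid on this same nitrogen would read in this assay on either core.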